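Returning a branched alkyl in place of chloro

The compounds below may be only part of what the source reports. "The series", "measured", "known", "first", "only" and "open" are said of these compounds alone.

Compound 1 `N#Cc1cc(C(=O)N2CS(=O)(=O)c3ccccc32)cc(C2CC2)c1O` gives 19200 nM in an assay on tissue (RPTEC cells) for inhibition of solute carrier family 22 member 12 (Homo sapiens), read by scintillation counting, with stated times of 15 min and 2 h; on this read-out lower numbers stand for stronger inhibition and higher numbers for weaker inhibition. Compound 2 `N#Cc1cc(C(=O)N2CS(=O)(=O)c3ccccc32)cc(Cl)c1O` carries chloro where compound 1 carries cyclopropyl. In this assay compound 2 only reaches the limit of > 100000 nM in this assay, at which 1 of the 2 values shown sits, and gives > 100000 nM, so no number is known for it. Within the data shown here, the step of an at least 5.2-fold higher number from compound 1 to compound 2 (0.71 log units; beyond the scatter) is therefore a lower bound and is the only measured step in the set. Compound 3 `CC(C)c1cc(C(=O)N2CS(=O)(=O)c3ccccc32)cc(C#N)c1O` differs from compound 2 by isopropyl in place of chloro on an aromatic carbon. Among the measured compounds shown here, this change runs against the direction of the one measured step, exchanging the halogen for a branched alkyl group that resembles the cyclopropyl of compound 1, and that single step is the only guide. A fall in this assay of roughly the size of that step is therefore expected, and the working assumption is the step of an at least 4.0-fold lower number from compound 2 to compound 3 (0.60 log units; beyond the scatter). Compound 3 is estimated at 25000 nM with a range of 8000 nM to 80000 nM.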

Compound 3, half-maximal inhibitory concentration: 83300 nM
The estimate for compound 3 lay 3.3-fold (0.52 log units) below the measured number; measured number outside the range, above it.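

Isopropyl does not stand in for cyclopropyl at this position, ortho to a hydroxy group, in this assay: swapping one branched group for the other gives a 4.3-fold higher number from compound 1 to compound 3 (0.64 log units; beyond the scatter), so compound 1 remains the strongest of the three, with its steps to both others beyond the scatter. Compound 2 stands at a limit of the assay and not at a number: the limit of > 100000 nM in this assay, at which 1 of the 3 values shown sits. Against that limit, the exchange of chloro for isopropyl reads only as an at least 1.2-fold lower number from compound 2 to compound 3 (0.07 log units; that floor lies within the scatter), so returning a branched alkyl group does not by itself establish any gain.

On these data alone, how far chloro and isopropyl actually lie apart remains unknown. Also open, as far as these compounds go, is whether an ethyl, a tert-butyl or a cyclobutyl group here would match or pass cyclopropyl on the shared core.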